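This account rests on a few compounds, and the source may have more. Where it says the series, first, only, none or still open, it means among the compounds named here.

Compounds measured so far:
compound 1 `Cc1ccc(Nc2nc(C(F)(F)F)ccc2CNC(=O)C(C)c2ccc(NS(C)(=O)=O)c(F)c2)cc1C` — 39.3 nM
compound 2 `CC(C(=O)NCc1ccc(C(F)(F)F)nc1NCc1ccc(Cl)cc1)c1ccc(NS(C)(=O)=O)c(F)c1` — 65.7 nM

In a functional assay on CHO-K1 cells for antagonist activity at transient receptor potential cation channel subfamily V member 1 (Homo sapiens), read by FLIPR (a lower number here means a stronger inhibitor, a higher number a weaker inhibitor), compound 2 gives the higher of the two numbers, with compound 1 the nearest; the step of a 1.7-fold higher number from compound 1 to compound 2 (0.22 log units; within the scatter) is within the scatter, so the two read as equivalent.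

Compound 3 `CC(C(=O)NCc1ccc(C(F)(F)F)nc1N(C)C)c1ccc(NS(C)(=O)=O)c(F)c1` has not been measured. It differs from compound 2 by dimethylamino in place of (4-chlorobenzyl)amino on an aromatic carbon of a six-membered aromatic ring with 1 nitrogen. Going by the values given here, the only measured step, from compound 1 to compound 2, exchanges one ring-bearing group for another at that same nitrogen and stays within the scatter; it does not cover removal of the ring altogether, and no other step bears on it. Taking the loss of the aromatic ring and of the hydrogen-bond donor into account, a clearly weaker result in this assay is expected, with the step of a 9.1-fold higher number from compound 2 to compound 3 (0.96 log units; beyond the scatter) expected to lie beyond the scatter. For compound 3 the estimate is 600 nM, within a range of 150 nM to 3000 nM.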

Compound 3, inhibition constant: 19.1 nM
Compound 3: middle estimate off by 31-fold (1.50 log units), on the high side, outside the stated range (below it).
By their numbers in this assay, from the lowest: compound 3; then compounds 1 and 2 (each within the scatter of the next).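

In this assay, the aromatic ring and the hydrogen-bond donor of the earlier amino groups are not required at this aromatic carbon: dimethylamino, with no ring and 0 hydrogen-bond donors, gives a 3.4-fold lower number from compound 2 to compound 3 (0.54 log units; beyond the scatter) and a 2.1-fold lower number from compound 1 to compound 3 (0.31 log units; beyond the scatter), both modest steps beyond the scatter. Going by these compounds alone, the earlier comparison exchanged only one ring-bearing group for another, a 1.7-fold higher number from compound 1 to compound 2 (0.22 log units; within the scatter), and so could not show that a group of 3 heavy atoms, against 9 in (4-chlorobenzyl)amino, is accepted here and reads stronger than either ring-bearing group. No measurement at hand accounts for this gain.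

In both new steps the ring and the hydrogen-bond donor leave together, so the compounds shown leave open which of the two losses, if either, goes with the lower number. Methylamino, which has a hydrogen-bond donor and no ring, and piperidine, which has a non-aromatic ring and no hydrogen-bond donor, would separate the two changes on this same aromatic carbon and show whether the gain holds beyond dimethylamino.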